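The source may report more compounds than this note shows. Statements on the series, on what has been measured and on what is new or still open speak of the compounds shown alone.

Compound 1 `CCOC(=O)c1cnc(NN2C(=O)C=C(C)C2=O)nc1CC` is measured in a functional assay on Jurkat cells (Homo sapiens) for inhibition (on this read-out higher numbers stand for weaker inhibition and lower numbers for stronger inhibition), where compound 1 gives 400 nM, the lower of the two single numbers in this series. Its nearest neighbour is compound 2 `CCOC(=O)c1cnc(NN2C(=O)C=C(C)C2=O)nc1Cc1ccccc1`, which in this assay gives 3800 nM; the step of a 9.5-fold higher number from compound 1 to compound 2 (0.98 log units; beyond the scatter) comes from a phenyl in place of methyl on a saturated chain carbon bound to an aromatic carbon. Compound 3 `CCOC(=O)c1cnc(N(C)N2C(=O)C=C(C)C2=O)nc1C(F)(F)C(F)(F)F` carries a methyl on the ring nitrogen together with a pentafluoroethyl group, and in this assay compound 3 gives 350 nM; 450 nM (2 entries), numbers close to that of compound 1; the repeat entries the several entries of compound 3 in this assay, 350 nM; 450 nM (2 entries) show how tightly one compound can be measured.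

Compound 4 `CCOC(=O)c1cnc(N(C)N2C(=O)C=C(C)C2=O)nc1CC` differs from compound 1 only by methyl in place of hydrogen on a nitrogen on an aromatic ring. Going by the values given here, no measured step isolates this change, and the one step on record, from compound 1 to compound 2, touches a different part of the molecule. Compound 4 is therefore expected to sit close to compound 1, with a step of no change at the digits printed from compound 1 to compound 4 (within the scatter) not beyond the scatter, and an estimated value of 400 nM, within 150 nM to 1100 nM.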

Compound 4, half-maximal inhibitory concentration: 35 nM
Compound 4: the middle estimate sits 11-fold (1.06 log units) above what was measured; measured number outside the range, below it.
By their numbers in this assay, from the lowest: compound 4; then compound 1; then compound 2.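

In this assay, going by these compounds alone, the nitrogen on the aromatic ring proves to be a sensitive place, something no earlier pair could show: a methyl in place of the hydrogen gives an 11-fold lower number from compound 1 to compound 4 (1.06 log units; beyond the scatter). Within the data shown here, this is the first change to move the number downward, whereas the only earlier step, a 9.5-fold higher number from compound 1 to compound 2 (0.98 log units; beyond the scatter), went upward and lay elsewhere in the molecule. The new step is also much wider than the spread between repeat measurements of a single compound: the several entries of compound 3 in this assay, 350 nM; 450 nM (2 entries)

Going by these compounds, compound 3 also carries this methyl, but it has no partner with a hydrogen on that nitrogen, so whether the drop holds with pentafluoroethyl in place of the ethyl group remains open. Also open, on these data alone, is how a propyl chain or an acetyl group on this same nitrogen would read.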